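Isopropyl Removal Repeated on Two Related Cores

The compounds below may be only part of what the source reports. "The series", "measured", "known", "first", "only" and "open" are said of these compounds alone.

The study covers four closely related compounds tested in a functional assay on A549 cells (Homo sapiens) for cytotoxicity, read by MTT assay; a lower number here means a stronger inhibitor, a higher number a weaker inhibitor. Compound 1 `C=C1[C@H](OC(C)=O)C[C@H](OC(C)=O)[C@@]2(C)[C@@H](OC(C)=O)C[C@@H](OC(C)=O)[C@]3(CO3)[C@@H]2[C@H](OC(C)=O)[C@]2(O)[C@@H](C)C(=O)O[C@H]2[C@H]1Cl` gives only a limit there, < 1500 nM, which is the limit described by the limit of < 1500 nM in this assay, at which 1 of the 3 values shown sits. Compound 2 `C=C1[C@H](OC(C)=O)C[C@H](OC(C)=O)[C@@]2(C)[C@@H](OC(=O)CC(C)C)C[C@@H](OC(C)=O)[C@]3(CO3)[C@@H]2[C@H](OC(C)=O)[C@]2(O)[C@@H](C)C(=O)O[C@H]2[C@H]1Cl` gives 18000 nM in this assay. The two differ in one place: hydrogen in place of isopropyl on a saturated chain carbon bound to a carbonyl carbon. Measured, this step reads an at least 12-fold lower number from compound 2 to compound 1 (1.07 log units; beyond the scatter).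

Compound 3 `C=C1[C@H]2O[C@]3([C@@H](C)C(=O)O[C@H]3[C@H]1Cl)[C@@H](OC(C)=O)[C@H]1[C@@]3(CO3)[C@H](OC(=O)CC(C)C)C[C@H](OC(C)=O)[C@]1(C)[C@@H](OC(C)=O)[C@H]2OC(C)=O` stands on a different core; how its core differs from that of compound 2 is not broken down here. In this assay compound 3 gives only a limit, < 300 nM, the limit described by the limit of < 300 nM in this assay, at which 1 of the 3 values shown sits. Compound 4 `C=C1[C@H]2O[C@]3([C@@H](C)C(=O)O[C@H]3[C@H]1Cl)[C@@H](OC(C)=O)[C@H]1[C@@]3(CO3)[C@H](OC(C)=O)C[C@H](OC(C)=O)[C@]1(C)[C@@H](OC(C)=O)[C@H]2OC(C)=O` has not yet been measured in this assay. It differs from compound 3 in one place: hydrogen in place of isopropyl on a saturated chain carbon bound to a carbonyl carbon. The place reads the same as in the step from compound 2 to compound 1, so the two changes are the same change carried out on two different cores.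

For compound 4 an improvement is expected, estimated at a step that the limit leaves unreadable from compound 3 to compound 4, resting on the earlier step of an at least 12-fold lower number from compound 2 to compound 1 (1.07 log units; beyond the scatter) and on the fact that compound 3 is already known only by a limit. As compound 3 gives a limit, compound 4 may well return a limit again rather than a number. Compound 4 is accordingly estimated at 100 nM, with an expected range from 10 nM to 300 nM.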

Compound 4, half-maximal inhibitory concentration: > 45700 nM
Compound 4: a limit, no number; the forecaster's own chance of this, stated with the estimate: 65%; middle value at least 450-fold (2.65 log units) from the limit.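

In this assay compound 4 gives > 45700 nM, which is a limit of the assay and not a number. From the compounds shown here alone, exchanging isobutylcarbonyl for acetyl on this core makes compound 4 a far weaker inhibitor, with a step of an at least 150-fold higher number from compound 3 to compound 4 (2.18 log units; beyond the scatter), so the gain seen on the core of compound 1 does not carry over and the same change runs in opposite directions on the two cores: the same change on two cores in this assay, an at least 12-fold lower number (1.07 log units; beyond the scatter) from compound 2 to compound 1 and an at least 150-fold higher number (2.18 log units; beyond the scatter) from compound 3 to compound 4, at least 1800-fold (3.26 log units) apart, beyond the scatter of two such steps This shows that, within these four compounds, the effect of the change depends on the core it is made on, but it rests on a single pair per core, and since compounds 1, 3 and 4 are known only by limits, the true sizes of both steps and of the gap between them stay unknown, and it does not show which feature of the cores reverses the outcome.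

The compounds shown leave open which of the differences between the two cores governs the reversal. They also leave open how an ester with a longer chain than acetyl but a different shape from isobutylcarbonyl, or one carrying an amine or a carboxylic acid, would behave at this place on either core.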